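A few compounds are considered here, and "the series" means these few. Any claim that something is new, unique, unknown or untested is made for them only; others in the source may bear on it.

Measured compounds:

- compound 1, `COc1cc(-c2nnc(SCc3ccc(C)cc3)o2)ccc1O`: 549000 nM
- compound 2, `COc1cc(-c2nnc(SCc3c(F)cccc3F)o2)ccc1O`: 575000 nM
- compound 3, `COc1cc(-c2nnc(SCc3ccc(F)cc3F)o2)ccc1O`: 520000 nM

All three share one core and differ only in the aryl group carried on a saturated chain carbon bound to a sulfur. In an ADME assay on cells (Mus musculus, strain BALB/c) for cytotoxicity, read by MTT assay, with a stated time of 24 h (on this read-out higher numbers stand for lower toxicity in this test and lower numbers for higher toxicity in this test), compound 3 gives the lowest of the three numbers, yet every gap among them is small: the step of a 1.1-fold lower number from compound 1 to compound 3 (0.02 log units; within the scatter) and the step of a 1.1-fold lower number from compound 2 to compound 3 (0.04 log units; within the scatter) both stay within the scatter, as does a 1.0-fold higher number from compound 1 to compound 2 (0.02 log units; within the scatter). On these numbers the three compounds cannot be told apart.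

Compound 4, `COc1cc(-c2nnc(SCc3ccccc3Cl)o2)ccc1O`, has not yet been measured. Compared with compound 3 the change is 2-chlorophenyl in place of 2,4-difluorophenyl on a saturated chain carbon bound to a sulfur. Within the data shown here, every measured step so far swaps one aryl group for another at this very position, and none moved the number beyond the scatter, so this further swap is expected to behave the same way. For compound 4 in this assay the expected step is a 1.0-fold higher number from compound 3 to compound 4 (0.02 log units; within the scatter), that is, no change beyond the scatter. Compound 4 is therefore estimated at 540000 nM, with a range from 300000 nM to 950000 nM.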

Compound 4, half-maximal cytotoxic concentration: 564000 nM
Beside the measured number, compound 4's estimate is 1.0-fold (0.02 log units) below it; low and high end bracket the measured number.
By their numbers in this assay, from the lowest: compounds 3, 1, 4 and 2 (each within the scatter of the next).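

Among these compounds, compound 4 puts a chlorine on the ring at this position for the first time, as 2-chlorophenyl, where compounds 2 and 3 carry two fluorines and compound 1 carries a methyl group. In this assay this new atom makes no difference that can be told apart, with a 1.1-fold higher number from compound 3 to compound 4 (0.04 log units; within the scatter) and a 1.0-fold lower number from compound 2 to compound 4 (0.01 log units; within the scatter) and also a 1.0-fold higher number from compound 1 to compound 4 (0.01 log units; within the scatter) as the three steps, so all four aryl groups on the saturated chain carbon bound to a sulfur now stand level within the scatter, and the tolerance seen for fluorine and methyl extends to a single chlorine. Nothing at hand explains why these numbers stay so close together.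

As far as these compounds go, all four groups are phenyl rings bearing only fluorine, chlorine or methyl, so it remains open whether a ring carrying an amine or a carboxylic acid, or a longer chain in place of the ring, would also stay within the scatter. All four compounds also keep the shared core, so what a change anywhere else in the molecule would do to the number is equally unanswered.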